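Dropping the bromo from compound 1

A few compounds are considered here, and "the series" means these few. Any claim that something is new, unique, unknown or untested is made for them only; others in the source may bear on it.

Measured so far:
- compound 1, `O=[N+]([O-])c1ccccc1CNc1cc(Br)cc2[nH]ncc12`: 39000 nM
- compound 2, `O=[N+]([O-])c1ccc(O)cc1CNc1cc(Br)cc2[nH]ncc12`: 460 nM
- compound 3, `CNC(=O)c1cccc(CNc2cc(C(F)(F)F)cc3[nH]ncc23)c1`: 4870 nM

In an assay for inhibition of Tryptophan 2,3-dioxygenase (Homo sapiens), with stated times of 10 min and 60 min (on this read-out higher numbers stand for weaker inhibition and lower numbers for stronger inhibition), compound 1 gives the highest number of the three, so it is the weakest inhibitor shown. Compound 3 comes nearest, and compound 2 lies furthest away. Going by the values given here, the only single change measured here is the one leading an 85-fold lower number from compound 1 to compound 2 (1.93 log units; beyond the scatter), a large gain from a hydroxy on the side ring.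

Compound 4, `O=[N+]([O-])c1ccccc1CNc1cccc2[nH]ncc12`, differs from compound 1 by hydrogen in place of bromo on an aromatic carbon. Among the compounds with values here, no measured step touches this position on the core: the step from compound 1 to compound 2 changes a different ring, and compound 3 differs from compound 1 in several places at once, so its value shows only that a core carrying trifluoromethyl together with a different side group sits lower than compound 1. With no guide for removing the bromo, the expectation for compound 4 is a modest rise in number, a 1.8-fold higher number from compound 1 to compound 4 (0.25 log units; within the scatter), and with wide uncertainty compound 4 is estimated at 70000 nM, within 20000 nM to 200000 nM.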

Compound 4, half-maximal inhibitory concentration: 17000 nM
Beside the measured number, compound 4's estimate is 4.1-fold (0.61 log units) above it, and the stated range ends above it.
By their numbers in this assay, from the lowest: compound 2; then compound 3; then compound 4; then compound 1.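

In this assay, going by these compounds alone, the first change measured on the shared core, hydrogen in place of bromo, gives a 2.3-fold lower number from compound 1 to compound 4 (0.36 log units; beyond the scatter) and so lies beyond the usual scatter, which means that in this pair the bromo brings no gain and the compound without it is the stronger inhibitor. The step is modest beside the one on the side ring, an 85-fold lower number from compound 1 to compound 2 (1.93 log units; beyond the scatter) on the same read-out, so on the nitro-bearing scaffold of compound 1 this position on the core moves the number far less than the hydroxy does, and compound 4 still sits high among the compounds shown. No measurement available here gives a reason for the drop in number on losing the bromo.

The compounds shown leave open whether the same step would appear with the hydroxy in place, since compound 2 has no partner lacking the bromo. They also leave open how a smaller or different group on this carbon, such as a chloro, a methoxy or an amine, would compare with the hydrogen of compound 4 and the bromo of compound 1.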